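A few compounds are considered here, and "the series" means these few. Any claim that something is new, unique, unknown or untested is made for them only; others in the source may bear on it.

In an ADME assay on microsomes from liver (Mus musculus) for metabolic stability (on this read-out lower numbers stand for slow clearance and higher numbers for fast clearance), compound 1 `Cc1ccc(S(=O)(=O)Nc2ccc(CN(C)[C@@H]3CCN(C(=O)c4cccc(Cl)c4)C3)cc2)cc1` gives > 50 mL.min-1.g-1, which is a limit of the assay and not a number. Compound 2 `Cc1ccc(S(=O)(=O)Nc2ccc(CN(C)[C@H]3CCN(C(=O)c4cccc(Cl)c4)C3)cc2)cc1` gives > 50 mL.min-1.g-1, also only a limit. Among the compounds with values here, the series so far therefore stands entirely at the limit of > 50 mL.min-1.g-1 in this assay, at which 2 of the 2 values shown sit. Within the data shown here, the one measured comparison is a step that the two limits leave unreadable from compound 1 to compound 2, resting on (the fact that compounds 1 and 2 differ only in the configuration as drawn), and it offers no size to carry over to a change at the nitrogen. The next structure is compound 3 `Cc1ccc(S(=O)(=O)Nc2ccc(CN[C@H]3CCN(C(=O)c4cccc(Cl)c4)C3)cc2)cc1`, with hydrogen in place of methyl on an amine nitrogen. Among the measured compounds shown here, no measured step covers this replacement, so no shift beyond the scatter is expected in this assay, and no direction is favoured. The expected change is a number no higher from compound 2 to compound 3 (the limit leaves the size open). Compound 3 is estimated at 50 mL.min-1.g-1, with an expected range of 22 mL.min-1.g-1 to 110 mL.min-1.g-1, and it may again return only a limit.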

Compound 3, intrinsic clearance in microsomes in the Mus musculus assay: > 50 mL.min-1.g-1
Compound 3: a limit, no number (the forecaster's own chance of this, stated with the estimate: 50%); the middle value sits exactly at the limit.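

In the Mus musculus assay compound 3 gives > 50 mL.min-1.g-1, a limit of the assay and not a number. No step can be read from compound 2 to compound 3 on this read-out. The compounds shown leave open whether hydrogen in place of methyl on an amine nitrogen shifts clearance at all. In a physicochemical assay for solubility, measured as kinetic solubility (on this read-out lower numbers stand for lower solubility and higher numbers for higher solubility), compound 2 gives 27000 nM and compound 3 gives 72000 nM, which is a 2.7-fold higher number from compound 2 to compound 3 (0.43 log units; beyond the scatter).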